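Removing the acetyl group: what solubility to expect

A few compounds are considered here, and "the series" means these few. Any claim that something is new, unique, unknown or untested is made for them only; others in the source may bear on it.

In a physicochemical assay for solubility, in phosphate buffer, at pH 6.5 (a lower number here means a less soluble compound, a higher number a more soluble compound), compound 1 `CNc1nc(NCCCN(C)C)c2sc(-c3ccc(N)cc3)cc2n1` gives 12.5 ug/mL.
Compound 2 `CNc1nc(NCCCN(C)C)c2sc(-c3ccc(C(C)=O)cc3)cc2n1` gives 12.5 ug/mL.
For compound 3 `CNc1nc(NCCCN(C)C)c2sc(-c3ccc(C(F)(F)F)cc3Cl)cc2n1` the assay gives only a limit, > 100 ug/mL.

Compound 2 thus stands level with compound 1 on the numbers shown; the one measured step that changes a single group, no change at the digits printed from compound 1 to compound 2 (within the scatter), stays within the scatter. Compound 4 `CNc1nc(NCCCN(C)C)c2sc(-c3ccccc3)cc2n1` differs from compound 2 in one place: hydrogen in place of acetyl on an aromatic carbon. Going by the values given here, the only measured step that bears on this swap at the same position is the one from compound 1 to compound 2, and it left this assay unchanged, so no step beyond the scatter is expected here: a 1.4-fold higher number from compound 2 to compound 4 (0.16 log units; within the scatter). Compound 4 is accordingly estimated at 18 ug/mL, with a range from 6 ug/mL to 60 ug/mL.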

Compound 4, solubility: > 100 ug/mL
Compound 4: no number, only a limit; the forecaster's own chance of this, stated with the estimate: 10%; at least 5.5-fold (0.74 log units) between middle value and limit.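

In this assay, acetyl and amino at this place, para to a large group, read the same, which hid how much having any group there matters. Hydrogen in place of acetyl gives an at least 8.0-fold higher number from compound 2 to compound 4 (0.90 log units; beyond the scatter), and hydrogen in place of amino gives an at least 8.0-fold higher number from compound 1 to compound 4 (0.90 log units; beyond the scatter), so the bare phenyl separates clearly from both. These steps are minimum sizes, and their full size stays unknown: the limit of > 100 ug/mL in this assay, at which 2 of the 4 values shown sit.

Going by these compounds, it remains open how a small group such as fluoro or methyl, or a carboxylic acid, would read at this place. Whether such groups would stay near hydrogen or near acetyl and amino cannot be told from these compounds.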